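This account rests on a few compounds, and the source may have more. Where it says the series, first, only, none or still open, it means among the compounds named here.

In an ADME assay on RAW264.7 cells (Mus musculus) for cytotoxicity, read by MTT assay, with a stated time of 72 h, tested at 50 uM (a higher number here means more inhibition at the concentration tested (going by the name of the read-out), a lower number less inhibition), compound 1 `CCOC(=O)c1sc(-c2ccccc2)nc1N1CCC(NCc2ccccc2)CC1` gives 11.7%. Compound 2 `CCOC(=O)c1sc(-c2ccccc2)nc1N1CCC(NCc2ccc(F)cc2)CC1` gives 6.23% in this assay. The one measured step, a number 5.5 percentage points lower from compound 1 to compound 2 (within the scatter), lies within the scatter, so on the numbers shown compound 2 stands level with compound 1: the two values cannot be told apart by this assay.

Compound 3 `CCOC(=O)c1sc(-c2ccccc2)nc1N1CCC(NCc2ccc(OC)cc2)CC1` differs from compound 2 in one place: methoxy in place of fluoro on an aromatic carbon. Within the data shown here, only one step is available for comparison, the exchange of hydrogen for fluoro on the same aromatic carbon between compound 1 and compound 2, and that step was a number 5.5 percentage points lower from compound 1 to compound 2 (within the scatter), a change within the scatter. Among the measured compounds shown here, no measured compound carries a methoxy group at this place, so there is nothing to show how methoxy behaves here. For the measured compounds named here, since the one change made at this position left this assay unmoved, the expectation for this assay is a step from compound 2 to compound 3 of a number 2.8 percentage points higher from compound 2 to compound 3 (within the scatter), that is, nothing beyond the scatter. Compound 3 is therefore estimated to give 9% in this assay, with a range from 0% to 25%.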

Compound 3, a percentage reported as inhibition, at one concentration (the size of the read-out at that concentration, not a potency): 8.4%
Beside the measured number, compound 3's estimate is 0.6 percentage points above it; measured number inside the range.
By their numbers in this assay, from the lowest: compounds 2, 3 and 1 (each within the scatter of the next).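

In this assay, putting methoxy where compound 2 has fluoro gives a number 2.2 percentage points higher from compound 2 to compound 3 (within the scatter), and putting methoxy where compound 1 has hydrogen gives a number 3.3 percentage points lower from compound 1 to compound 3 (within the scatter). Where the earlier compounds offered only the exchange of hydrogen for fluoro, this position on the aromatic ring, para to a large group, has now carried three different groups, and this assay cannot tell any of the three compounds apart, even though methoxy brings more heavy atoms than fluoro and a hydrogen-bond acceptor that fluoro is not counted as having. Nothing among the data shown explains why the read-out stays so level across these changes.

Still open, as far as these compounds go, is whether this flat picture holds for groups of a different kind at the same place, such as an amine, a carboxylic acid or a longer chain like butoxy, any of which might or might not produce a step beyond the scatter. Also open, from the compounds shown here alone, is whether changes elsewhere in the molecule, for instance at the ethyl ester, would move the read-out, since all three compounds share that part unchanged.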